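Aryl amide variation across a shared core

The source may hold more compounds than are shown below. What is called first, only, known or untested is meant among the compounds shown, and "the series" means these compounds.

compound 1 `O=C(Nc1cccc(-c2oc3cc(-c4ccc(F)cc4)ccc3c(=O)c2O)c1)c1ccccc1F`: 4410 nM
compound 2 `O=C(Nc1cccc(-c2oc3cc(-c4ccc(F)cc4)ccc3c(=O)c2O)c1)c1ccc(Br)cc1`: 13500 nM
compound 3 `Cc1cc(C(=O)Nc2cccc(-c3oc4cc(-c5ccc(F)cc5)ccc4c(=O)c3O)c2)ccc1F`: 11500 nM

In a functional assay on A549 cells (Homo sapiens) for antiproliferative activity, read by CCK-8 assay, with a stated time of 72 h (a lower number here means a stronger inhibitor, a higher number a weaker inhibitor), compound 3 gives 11500 nM, the second highest of the three numbers. The nearest measured neighbour is compound 2, with a 1.2-fold lower number from compound 2 to compound 3 (0.07 log units; within the scatter); the furthest is compound 1, with a 2.6-fold higher number from compound 1 to compound 3 (0.42 log units; beyond the scatter). Compound 4 `O=C(Nc1cccc(-c2oc3cc(-c4ccc(F)cc4)ccc3c(=O)c2O)c1)c1cc(F)cc(F)c1` carries 3,5-difluorophenyl in place of 4-fluoro-3-methylphenyl on a carbonyl carbon. Within the data shown here, the steps that bear on this exchange are the two aryl swaps on the carbonyl carbon: a 3.1-fold higher number from compound 1 to compound 2 (0.49 log units; beyond the scatter) and a 2.6-fold higher number from compound 1 to compound 3 (0.42 log units; beyond the scatter), both modest, and a 1.2-fold lower number from compound 2 to compound 3 (0.07 log units; within the scatter), within the scatter. Two swaps among aryl groups without the 2-fluorophenyl pattern moved little, so for compound 4 no step beyond the scatter is expected in this assay, a 1.3-fold lower number from compound 3 to compound 4 (0.11 log units; within the scatter). Compound 4 is estimated at 9000 nM, with a range from 3500 nM to 24000 nM.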

Compound 4, half-maximal inhibitory concentration: 7620 nM
Estimate against measurement, compound 4: 1.2-fold (0.07 log units) above; the measured number falls inside the stated range.
By their numbers in this assay, from the lowest: compounds 1, 4, 3 and 2 (each within the scatter of the next, the first and the last beyond it).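

In this assay the 3,5-difluorophenyl group does not separate from any other aryl group on this carbonyl carbon, with a 1.5-fold lower number from compound 3 to compound 4 (0.18 log units; within the scatter) and a 1.8-fold lower number from compound 2 to compound 4 (0.25 log units; within the scatter) and also a 1.7-fold higher number from compound 1 to compound 4 (0.24 log units; within the scatter) all within the scatter. The one gap beyond the scatter, between compound 1 and compounds 2 and 3, is thus bridged by compound 4, which lies within the scatter of both sides. No evidence here bears on the cause.

As far as these compounds go, all four amides carry a substituted phenyl ring, so a basic amine, a carboxylic acid or a saturated ring at this position remains open.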